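The source may hold more compounds than are shown below. What is called first, only, known or untested is meant among the compounds shown, and "the series" means these compounds.

Compound 1 `COc1ccc(S(=O)(=O)N2CCc3cccc(NC(=O)Oc4ccccc4)c32)cc1`: > 10000 nM
Compound 2 `COc1ccc(S(=O)(=O)N2CCc3cc(Br)cc(NC(=O)c4ccncc4)c32)cc1`: 86 nM

In a functional assay on MKN-45 cells (Homo sapiens) for cytotoxicity (on this read-out higher numbers stand for weaker inhibition and lower numbers for stronger inhibition), compound 1 stands at > 10000 nM, which is a limit of the assay and not a number. Compound 2 gives a measured 86 nM in this assay.

Compound 3 `COc1ccc(S(=O)(=O)N2CCc3cccc(NS(=O)(=O)c4ccccc4)c32)cc1` keeps the core of compound 1 and changes one group, with phenylsulfonyl in place of phenoxycarbonyl on a nitrogen on an aromatic ring.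

A modest move towards stronger inhibition in this assay is expected, and the estimated size is an at least 2.0-fold lower number from compound 1 to compound 3 (0.30 log units; that floor lies within the scatter). Compound 3 is expected at 5000 nM, with an estimated range of 500 nM to 10000 nM.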

Compound 3, half-maximal inhibitory concentration: 562 nM
Estimate against measurement, compound 3: 8.9-fold (0.95 log units) above, within the range that was stated.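

In this assay, phenylsulfonyl in place of phenoxycarbonyl on a nitrogen on an aromatic ring gives an at least 17-fold lower number from compound 1 to compound 3 (1.25 log units; beyond the scatter), so on the core of compound 1 the group carried by this nitrogen matters. The true size of that step remains unknown, because compound 1 stands at a limit of the assay and not at a number: the limit of > 10000 nM in this assay, at which 1 of the 3 values shown sits.

Still open, from the compounds shown here alone, is whether the sulfonyl link or its phenyl ring accounts for the step, which methylsulfonyl on the same nitrogen could help separate. Compound 2 differs from compound 3 in more than one place, so it cannot settle this.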